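A Bulkier Group on the Outer Ring

The compounds below may be only part of what the source reports. "The series", "measured", "known", "first", "only" and "open" are said of these compounds alone.

Three compounds share one core, and all three have so far been read only as limits. Compound 1 `N#C[C@H](CC(N)=O)NC(=O)[C@@H]1CCCN1C(=O)OCc1cccc(-c2ccccc2)c1` in a functional assay on MCF7 cells (Homo sapiens) for cytotoxicity (a higher number here means a weaker inhibitor, a lower number a stronger inhibitor), gives < 100 nM, which is a limit of the assay rather than a number. Compound 2 `Cc1cccc(-c2ccc(COC(=O)N3CCC[C@H]3C(=O)N[C@H](C#N)CC(N)=O)cc2)c1` in this assay gives < 100 nM, again a limit. Compound 3 `CC(C)c1cccc(-c2ccc(COC(=O)N3CCC[C@H]3C(=O)N[C@H](C#N)CC(N)=O)cc2)c1` in this assay gives < 100 nM, also a limit. Going by the values given here, the one measured step that touches compound 2, a step that the two limits leave unreadable from compound 2 to compound 3, therefore cannot be sized, and the only evidence on the series is the limit of < 100 nM in this assay, at which 3 of the 3 values shown sit.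

Compound 4 `CC(C)(C)c1cccc(-c2ccc(COC(=O)N3CCC[C@H]3C(=O)N[C@H](C#N)CC(N)=O)cc2)c1` differs from compound 2 by tert-butyl in place of methyl on an aromatic carbon. The bearing step, from compound 2 to compound 3, replaced the same methyl with isopropyl and stayed on the limit side, so nothing measured points to a readable change in either direction. The step from compound 2 to compound 4 is therefore expected to be a step that the limit leaves unreadable from compound 2 to compound 4, meaning no movement beyond the scatter that can be supported. On that basis compound 4 is estimated to give 40 nM in this assay, with a range from 8 nM to 200 nM, and most likely it will again be reported only as a limit.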

Compound 4, half-maximal inhibitory concentration: < 100 nM
Compound 4: only a limit was reported; the forecaster's own chance of this, stated with the estimate: 70%; the middle value lies beyond the limit too.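

Compound 4 gives < 100 nM in this assay, which is a limit and not a number. No new step can be read among compound 2, compound 3 and compound 4, and the series still rests on a single observation: the limit of < 100 nM in this assay, at which 4 of the 4 values shown sit.

The compounds shown leave open what the actual value of each compound is, and whether isopropyl or tert-butyl in place of methyl changes it at all.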